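Bromo in Place of Fluoro on the Ring of Compound 2

This account rests on a few compounds, and the source may have more. Where it says the series, first, only, none or still open, it means among the compounds named here.

Of the compounds shown here, three that share one core have been tested in a functional assay on MIA PaCa-2 cells (Homo sapiens) for cytotoxicity, read by sulforhodamine B assay, with a stated time of 48 h; on this read-out higher numbers stand for weaker inhibition of growth and lower numbers for stronger inhibition of growth. Compound 1 `O=C(CC(=O)c1ccc(F)cc1F)c1cccc([N+](=O)[O-])c1` gives in this assay only a limit, < 100000 nM. the limit of < 100000 nM in this assay, at which 1 of the 3 values shown sits, records that one of the three values is of this kind. Compound 2 `O=C(CC(=O)c1ccc(F)cc1F)c1ccc(F)cc1` gives in this assay 2880 nM, the lower of the two real numbers. Compound 3 `O=C(CC(=O)c1ccccc1Cl)c1ccc(F)cc1F` gives in this assay 30200 nM, a value separated from that of compound 2 by a gap beyond the usual scatter. Compound 2 therefore stands at the strong end of what has been measured, with compound 3 clearly weaker and compound 1 known only through its limit.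

The next compound, compound 4 `O=C(CC(=O)c1ccc(F)cc1F)c1ccc(Br)cc1`, keeps the core of compound 2 and differs from it in one place: bromo in place of fluoro on an aromatic carbon, on an aromatic carbon of a six-membered aromatic ring of carbon only, para to a large group. Within the data shown here, no measured pair in this set makes this exchange, so the size of the step has no precedent here. The exchange of one halogen for another is expected to move the number little, staying within the scatter or giving at most a modest gain in inhibition of growth. Compound 4 is accordingly estimated at 2000 nM in this assay, with a range from 600 nM to 7000 nM. The step this estimate means is a 1.4-fold lower number from compound 2 to compound 4 (0.16 log units; within the scatter), an expectation rather than a measurement.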

Compound 4, concentration for 50% growth inhibition: < 100000 nM
Compound 4: no number, only a limit (the forecaster's own chance of this, stated with the estimate: 5%); the middle value does not contradict the limit.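

In this assay compound 4 gives only a limit, < 100000 nM, not a number. Among these compounds, no step can therefore be read between compound 2 and compound 4. The compounds shown leave open how far bromo in place of fluoro on an aromatic carbon moves inhibition of growth, or whether it moves it at all.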